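The source may report more compounds than this note shows. Statements on the series, on what has been measured and on what is new or still open speak of the compounds shown alone.

Measured in a functional assay on MDA-MB-468 cells (Homo sapiens) for antiproliferative activity, read by MTT assay, with a stated time of 72 h; on this read-out lower numbers stand for stronger inhibition and higher numbers for weaker inhibition:
Compound 1 `CCCn1ccnc1-c1cc(OC)c(OC)c(OC)c1`: > 100000 nM, a limit
Compound 2 `COc1cc(-c2nccn2CC(C)C)cc(OC)c1OC`: > 100000 nM, a limit
Compound 3 `COc1cc(-c2nccn2-c2cccc(C)c2)cc(OC)c1OC`: 22600 nM

Compound 3 stands alone here with a true number, 22600 nM. The other two values are only limits. Compound 4 `COc1cc(-c2nccn2-c2ccc(F)cc2)cc(OC)c1OC` carries 4-fluorophenyl in place of 3-methylphenyl on an aromatic nitrogen. Within the data shown here, two measured steps bear on this place: an at least 4.4-fold lower number from compound 1 to compound 3 (0.64 log units; beyond the scatter) and an at least 4.4-fold lower number from compound 2 to compound 3 (0.64 log units; beyond the scatter). Among the measured compounds shown here, each puts 3-methylphenyl where a saturated chain stood, and no measured step swaps one such ring for another. Compound 4 keeps a six-membered aromatic ring of carbon only there, so no change beyond the scatter is expected in this assay. The expected step is a 1.1-fold higher number from compound 3 to compound 4 (0.04 log units; within the scatter). For compound 4 the estimate is 25000 nM, within an expected range of 8000 nM to 80000 nM.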

Compound 4, half-maximal inhibitory concentration: 62200 nM
Compound 4: the middle estimate sits 2.5-fold (0.40 log units) below what was measured, within the range that was stated.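

The earlier compounds shown here showed only that 3-methylphenyl on this nitrogen does better than a saturated chain; in this assay, the identity of the ring also matters, with a 2.8-fold higher number from compound 3 to compound 4 (0.44 log units; beyond the scatter). Against the chains, the 4-fluorophenyl ring gives an at least 1.6-fold lower number from compound 2 to compound 4 (0.20 log units; that floor lies within the scatter) and an at least 1.6-fold lower number from compound 1 to compound 4 (0.20 log units; that floor lies within the scatter), so the gain seen with 3-methylphenyl is not secured for this ring. These comparisons stay loose because both chain compounds rest on a limit: the limit of > 100000 nM in this assay, at which 2 of the 4 values shown sit.

The step changes both the substituent and its place on the ring, and the compounds shown do not separate the two. A 4-methylphenyl or 3-fluorophenyl group would do so.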